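The compounds below may be only part of what the source reports. "The series", "measured", "known", "first", "only" and "open" are said of these compounds alone.

Compound 1 `CCCC(Oc1ccc(-n2cc(C(F)(F)F)cn2)c(C)c1)c1ccc(C(=O)NCCC(=O)O)cc1`: 2.6
Compound 2 `CCCC(Nc1cc(C)c(-n2cc(C(F)(F)F)cn2)c(C)c1)c1ccc(C(=O)NCCC(=O)O)cc1`: 2.2
Compound 3 `CCCC(Oc1ccc(-n2cc(C#N)cn2)cc1)c1ccc(C(=O)NCCC(=O)O)cc1`: 1.2

These three compounds have been measured in a physicochemical assay for lipophilicity, using the shake flask method, at pH 7.4; a lower number here means a more polar compound, a higher number a more lipophilic compound. Compound 3 gives 1.2, the lowest of the three numbers. The nearest neighbour is compound 2 at 2.2, a gap that lies beyond the scatter, and the furthest is compound 1 at 2.6, a gap that also lies beyond the scatter. Compound 4 `CCCC(Oc1ccc(-n2cc3ccccc3n2)cc1)c1ccc(C(=O)NCCC(=O)O)cc1` has not yet been measured in this assay. It differs from compound 3 in a single place: 2H-indazol-2-yl in place of 4-cyano-1H-pyrazol-1-yl on an aromatic carbon. The group that leaves carries a triple bond outside aromatic rings; the group that enters brings one six-membered aromatic ring of carbon only fused to its five-membered aromatic ring. Among the compounds with values here, no step between measured compounds matches this exchange, so the expectation rests on the change alone. A clear rise in this assay is expected, and the step from compound 3 to compound 4 is estimated at a number 1.40 log units higher from compound 3 to compound 4 (beyond the scatter). Compound 4 is therefore expected to give about 2.6, with a range from 2.1 to 3.1.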

Compound 4, distribution coefficient: 2.5
Compound 4: middle estimate off by 0.10 log units, on the high side; the range from low to high includes it.
By their numbers in this assay, from the lowest: compound 3; then compounds 2, 4 and 1 (each within the scatter of the next, the first and the last beyond it).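

In this assay, putting 2H-indazol-2-yl in place of 4-cyano-1H-pyrazol-1-yl on this aromatic carbon, para to a large group, gives a number 1.30 log units higher from compound 3 to compound 4 (beyond the scatter). This is the first pair shown that differs in one place only, so the size of a change at this position can now be read directly, which compound 1 and compound 2 could not show. Nothing at hand explains the step.

The exchange removes a nitrile and adds a six-membered aromatic ring of carbon only, and this one pair cannot tell how much of the step belongs to each change. A plain 1H-pyrazol-1-yl group would separate the two, while an amine on the pyrazole ring would show how a quite different group behaves at this place.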